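Series notes: compound 2 to compound 3

The compounds below may be only part of what the source reports. "The series", "measured", "known", "first", "only" and "open" are said of these compounds alone.

In a functional assay on SEM cells (Homo sapiens) for cytotoxicity, with a stated time of 72 h (a lower number here means that less compound is needed, a higher number that more compound is needed for the effect), compound 1 `CCOc1ccc(/C=C/[C@@](C)(/C=C/c2ccc(O)cc2)CCC=C(C)C)cc1` is reported only as a limit, > 36600 nM. Compound 2 `CC(C)=CCC[C@](C)(/C=C/c1ccc(O)cc1)/C=C/c1ccc(C#N)cc1` is likewise reported only as a limit, > 36600 nM. Both measured compounds therefore sit at the same limit, as the limit of > 36600 nM in this assay, at which 2 of the 2 values shown sit, records, and compound 2 has no numerical position in the series.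

Compound 3 `CC(C)=CCC[C@](C)(/C=C/c1ccc(O)cc1)/C=C/c1cccc(F)c1` differs from compound 2 by 3-fluorophenyl in place of 4-cyanophenyl on a double-bonded chain carbon bound to a double-bonded chain carbon. Among the measured compounds shown here, the one measured step, a step that the two limits leave unreadable from compound 1 to compound 2, also exchanged a group on an aromatic carbon, but it yields no size to carry forward. Neither compound 1 nor compound 2 gives a readable number in this assay, so the data support no direction for the new change. Compound 3 is expected to stay close to the limit, and a further report of a limit is the likeliest outcome. The expected move is a step that the limit leaves unreadable from compound 2 to compound 3, an estimate that implies no real change in either direction. For compound 3 the estimated value is 40000 nM, with an expected range of 15000 nM to 80000 nM.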

Compound 3, half-maximal effective concentration: > 36600 nM
Compound 3 gave a limit, no number; the forecaster's own chance of this, stated with the estimate: 70%; the middle value does not contradict the limit.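

Compound 3 gives only a limit in this assay, as do compound 1 and compound 2, so no step among these three compounds can be read: the limit of > 36600 nM in this assay, at which 3 of the 3 values shown sit.

The compounds shown leave open whether 4-ethoxyphenyl, 4-cyanophenyl and 3-fluorophenyl differ at all in this assay, and which change on the shared core, if any, would give a readable number.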